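Chloro in place of trifluoromethyl: compound 3 expected

This account rests on a few compounds, and the source may have more. Where it says the series, first, only, none or still open, it means among the compounds named here.

In an ADME assay on a cell-free system (plasma, Homo sapiens) (on this read-out lower numbers stand for a smaller free fraction and higher numbers for a larger free fraction), compound 1 `CCc1c(CN2CC(C(=O)O)C2)cccc1-c1nsc(-c2ccc(OC(C)C)c(C(F)(F)F)c2)n1` gives 0.0026. Compound 2 `CCc1c(CN(C)CC(=O)O)cccc1-c1nsc(-c2ccc(OC(C)C)c(C(F)(F)F)c2)n1` gives 0.0049, and these two numbers lie within the scatter of each other, so neither stands apart. Compound 3 `CCc1c(CN2CC(C(=O)O)C2)cccc1-c1nsc(-c2ccc(OC(C)C)c(Cl)c2)n1` keeps the rest of compound 1 but carries chloro in place of trifluoromethyl on an aromatic carbon, ortho to an isopropoxy group: chloro in place of trifluoromethyl on an aromatic carbon. For the measured compounds named here, the only measured step is a 1.9-fold higher number from compound 1 to compound 2 (0.28 log units; within the scatter), which lies within the scatter. That step concerns a different part of the molecule, so it bears only indirectly on this swap. Going by the values given here, no measured step exists at this aromatic carbon, so nothing beyond the scatter is expected in this assay, and no firm direction can be given. The expected size of the change is a 1.2-fold higher number from compound 1 to compound 3 (0.09 log units; within the scatter). For compound 3 the estimated value is 0.0032, with an expected range from 0.0015 to 0.0068.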

Compound 3, unbound fraction: 0.0096
Compound 3: the middle estimate sits 3.0-fold (0.48 log units) below what was measured; measured number outside the range, above it.
By their numbers in this assay, from the lowest: compounds 1, 2 and 3 (each within the scatter of the next, the first and the last beyond it).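

For the compounds shown here, this is the first measured change at the aromatic carbon ortho to an isopropoxy group. In this assay, going by these compounds alone, chloro in place of trifluoromethyl gives a 3.7-fold higher number from compound 1 to compound 3 (0.57 log units; beyond the scatter) and so lies beyond the scatter, while the one earlier step, in the side chain, stayed within it; this carbon can therefore shift the free fraction, modestly, towards a larger value. Nothing available explains this shift, and a single swap cannot separate what chloro adds from what trifluoromethyl takes away.

The compounds shown leave open whether the same swap would have a similar effect on compound 2, with its (carboxymethyl)(methyl)amino side chain. They also leave open how other groups at this carbon, such as fluoro, methyl or methoxy, would compare with chloro and trifluoromethyl.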